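The compounds below may be only part of what the source reports. "The series", "measured", "known", "first", "only" and "open" are said of these compounds alone.

Of the compounds shown here, three have been measured in a physicochemical assay for solubility, read by HPLC, measured as kinetic solubility, with a stated time of 15 min; on this read-out lower numbers stand for lower solubility and higher numbers for higher solubility. Compound 1 `O=[N+]([O-])c1cn2c(n1)OC[C@H](OCc1ccc(-c3ccc(OC(F)(F)F)cc3Cl)cc1)C2` is one of them; in this assay compound 1 gives < 0.1 ug/mL, which is a limit of the assay rather than a number. Compound 2 `O=[N+]([O-])c1cn2c(n1)OC[C@H](OCc1ccc(-c3ccc(C(F)(F)F)cc3Cl)cc1)C2` is closely related; in this assay compound 2 gives < 0.1 ug/mL, again a limit and not a number. Compound 1 differs from compound 2 by trifluoromethoxy in place of trifluoromethyl on an aromatic carbon, and the step that the two limits leave unreadable from compound 2 to compound 1 stays unreadable because both values sit at the limit of < 0.1 ug/mL in this assay, at which 2 of the 3 values shown sit. Going by the values given here, compound 3 `O=[N+]([O-])c1cn2c(n1)OC[C@@H](OCC#Cc1ccc(-c3ccc(C(F)(F)F)cc3)cn1)C2` is the only one with a plain number: in this assay compound 3 gives 0.33 ug/mL. How the core of compound 3 differs from that of compound 2 is not broken down here.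

Compound 4 `O=[N+]([O-])c1cn2c(n1)OC[C@@H](OCC#Cc1ccc(-c3ccc(OC(F)(F)F)cc3)cn1)C2` has not yet been measured. It differs from compound 3 by trifluoromethoxy in place of trifluoromethyl on an aromatic carbon. Among the compounds with values here, this is the same kind of change as the one from compound 2 to compound 1, though in that pair the place is also meta to a chloro group. Since the measured example gives no readable size, the step of a 1.3-fold lower number from compound 3 to compound 4 (0.12 log units; within the scatter) is expected to be small. Compound 4 is estimated to give 0.25 ug/mL, with a likely range from 0.08 ug/mL to 0.8 ug/mL.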

Compound 4, solubility: 0.49 ug/mL
Estimate against measurement, compound 4: 2.0-fold (0.29 log units) below; measured number inside the range.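

In this assay, putting trifluoromethoxy in place of trifluoromethyl gives a 1.5-fold higher number from compound 3 to compound 4 (0.17 log units; within the scatter) and so, on the core of compound 3, the two groups cannot be told apart in this read-out. This is one pair on one core, so it says nothing general about the change across the series, and a step within the scatter gives no firm direction to carry elsewhere. It also cannot be checked against the same change from compound 2 to compound 1, a step that cannot be read because both values are limits of the assay and not numbers: the limit of < 0.1 ug/mL in this assay, at which 2 of the 4 values shown sit.

Whether the result holds on a core where a number can be read for both partners remains open, since only one readable pair is shown. Also open, going by these compounds, is what a different kind of group in the same place, such as an amine or a carboxylic acid, would do to the read-out on the core of compound 3.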